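The compounds below may be only part of what the source reports. "The series", "measured", "known", "first", "only" and "open" are said of these compounds alone.

Measured so far in a functional assay on HT-29 cells (Homo sapiens) for cytotoxicity, read by MTT assay, with a stated time of 72 h; on this read-out higher numbers stand for weaker inhibition and lower numbers for stronger inhibition:
compound 1, `CN(C)CCn1cnnc1-c1cc(Oc2ccc(NC(=O)N/N=C/c3ccc(Cl)cc3Cl)cc2F)ccn1`, gives 390 nM
compound 2, `CN(C)CCn1cnnc1-c1cc(Oc2ccc(NC(=O)N/N=C/c3ccccc3)cc2F)ccn1`, gives 1120 nM

Compound 2 stands highest of the two numbers; its nearest neighbour is compound 1, and the step of a 2.9-fold higher number from compound 1 to compound 2 (0.46 log units; beyond the scatter) is the only one that bears on the next change. Compound 3, `CN(C)CCn1cnnc1-c1cc(Oc2ccc(NC(=O)N/N=C/c3cccc(Br)c3)cc2F)ccn1`, differs from compound 2 by bromo in place of hydrogen on an aromatic carbon. Since removing both chlorines from compound 1 raised the number, putting one halogen back on the ring, meta to a large group, is expected to lower it somewhat, though not necessarily all the way. The expected step is a 1.9-fold lower number from compound 2 to compound 3 (0.27 log units; within the scatter), and compound 3 is estimated at 600 nM with a range of 250 nM to 1400 nM.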

Compound 3, half-maximal inhibitory concentration: 380 nM
For compound 3 the middle estimate is 1.6-fold (0.20 log units) above the measured one; low and high end bracket the measured number.
By their numbers in this assay, from the lowest: compounds 3 and 1 (each within the scatter of the next); then compound 2.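

In this assay, bromo in place of hydrogen on the phenyl ring, meta to a large group, gives a 2.9-fold lower number from compound 2 to compound 3 (0.47 log units; beyond the scatter), so a single substituent is enough for a step of this size; the earlier pair showed only the loss of both chlorines together. The 3-bromophenyl and 2,4-dichlorophenyl groups are not separated here, with a 1.0-fold lower number from compound 1 to compound 3 (0.01 log units; within the scatter) within the scatter. No measurement to hand accounts for this result.

Going by these compounds, whether a halogen is needed on this carbon remains open: a methyl, methoxy or nitrile group there could give a similar number or a different one. Also open, on these data alone, is whether chloro or fluoro at the same place would match bromo.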